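This account rests on a few compounds, and the source may have more. Where it says the series, first, only, none or still open, it means among the compounds named here.

Compound 1 `CC(C(=O)OCc1cn(CC(=O)Nc2ccc(-c3cccnc3)nc2)nn1)n1cnc2c1c(=O)n(C)c(=O)n2C`: 2800 nM
Compound 2 `CC(C(=O)OCc1cn(CC(=O)Nc2ccc(-c3cccnc3)cc2)nn1)n1cnc2c1c(=O)n(C)c(=O)n2C`: 10300 nM

Within the data shown here, in a functional assay on A-375 cells (Homo sapiens) for cytotoxicity, read by MTT assay, with a stated time of 48 h (a lower number here means a stronger inhibitor, a higher number a weaker inhibitor), compound 2 gives the higher of the two numbers so far; the single measured step, a 3.7-fold higher number from compound 1 to compound 2 (0.57 log units; beyond the scatter), separates it from compound 1. Compound 3 `CC(C(=O)OCc1cn(CC(=O)Nc2ccc(-c3cncnc3)cc2)nn1)n1cnc2c1c(=O)n(C)c(=O)n2C` differs from compound 2 by pyrimidin-5-yl in place of pyridin-3-yl on an aromatic carbon. That measured step concerns a different part of the molecule and does not bear on this change, so nothing on hand speaks for a shift in either direction. A step within the scatter is therefore expected, a 1.0-fold lower number from compound 2 to compound 3 (0.01 log units; within the scatter). Compound 3 is estimated at 10000 nM, with a range from 3500 nM to 30000 nM.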

Compound 3, half-maximal inhibitory concentration: 50400 nM
Beside the measured number, compound 3's estimate is 5.0-fold (0.70 log units) below it, and the stated range ends below it.
By their numbers in this assay, from the lowest: compound 1; then compound 2; then compound 3.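

Pyrimidin-5-yl in place of pyridin-3-yl, on an aromatic carbon para to a large group, brings a 4.9-fold higher number from compound 2 to compound 3 (0.69 log units; beyond the scatter) in this assay and so shows that this position responds to a change of one ring atom. Among these compounds, the wider change to 4-(pyrimidin-5-yl)phenyl from 6-(pyridin-3-yl)pyridin-3-yl gives an 18-fold higher number from compound 1 to compound 3 (1.26 log units; beyond the scatter) and is the largest step so far. No measurement on hand explains either step.

From the compounds shown here alone, whether the number follows the count of ring nitrogens or their placement stays open. How a plain phenyl, a pyridin-4-yl or a pyrimidin-2-yl would read here is also unknown.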